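Swapping One Ester Group in a Dihydropyridine Calcium-Channel Blocker

This account rests on a few compounds, and the source may have more. Where it says the series, first, only, none or still open, it means among the compounds named here.

Compound 1 `CSc1ncc(C2C(C(=O)OC(C)C)=C(C)NC(C)=C2C(=O)OC(C)C)n1Nc1ccccc1` was tested in an assay on isolated protein (strain albino) for antagonist activity at Voltage-dependent L-type calcium channel subunit alpha-1C (Cavia porcellus) (a lower number here means a stronger inhibitor, a higher number a weaker inhibitor), where compound 1 gives 2.16 nM. A second measured compound, compound 2 `CSc1ncc(C2C(C(=O)OCCCc3ccccc3)=C(C)NC(C)=C2C(=O)OCCCc2ccccc2)n1Nc1ccccc1`, carries two longer phenylpropyl esters in place of the two isopropyl esters; in this assay compound 2 gives 3.15 nM. These two numbers lie within the usual scatter of each other, so compound 1 and compound 2 cannot be told apart in potency, and no trend can be drawn from them.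

Compound 3 `CSc1ncc(C2C(C(=O)OC(C)C)=C(C)NC(C)=C2C(=O)OC(C)(C)C)n1Nc1ccccc1` is not yet measured. It differs from compound 1 by a small change: methyl in place of hydrogen on a saturated chain carbon bound to an oxygen next to a carbonyl group and two saturated chain carbons. Within the data shown here, no comparable step between measured compounds is available, so the expectation rests only on how little the shared core and the remaining groups are altered. The estimated step in this assay is a 1.4-fold higher number from compound 1 to compound 3 (0.14 log units; within the scatter), expected to stay within the scatter. Compound 3 is therefore estimated at 3 nM, with a range from 1 nM to 10 nM.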

Compound 3, half-maximal inhibitory concentration: 68.2 nM
Compound 3: middle estimate off by 23-fold (1.36 log units), on the low side, and the stated range ends below it.
By their numbers in this assay, from the lowest: compounds 1 and 2 (each within the scatter of the next); then compound 3.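

Replacing one isopropyl ester with a tert-butyl ester gives a 32-fold higher number from compound 1 to compound 3 (1.50 log units; beyond the scatter) in this assay and so weakens the compound well beyond the scatter. The earlier compounds shown here offered no single-place step to read, whereas this pair shows that potency can depend strongly on this ester: one methyl on the saturated chain carbon bound to the ester oxygen is enough to change the result markedly. The data at hand give no explanation for the size of this step.

The compounds shown leave open whether this sensitivity is specific to tert-butyl or extends to other groups at this place, such as a cyclopropyl or cyclobutyl ester. They also leave open how a smaller ethyl ester or a free carboxylic acid would behave here.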